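Bromo removal on the isatin-type core: cytotoxicity expectation

A few compounds are considered here, and "the series" means these few. Any claim that something is new, unique, unknown or untested is made for them only; others in the source may bear on it.

Compound 1 `O=C1C(=O)N(CN2CCN(c3ccnc4cc(C(F)(F)F)ccc34)CC2)c2cccc(Br)c21` and compound 2 `O=C1C(=O)N(CN2CCN(c3ccnc4cc(C(F)(F)F)ccc34)CC2)c2ccccc21` share a core and differ only by hydrogen in place of bromo on an aromatic carbon. In an ADME assay on MCF-10A cells (Homo sapiens) for cytotoxicity, read by sulforhodamine B assay, with a stated time of 48 h (a lower number here means a stronger inhibitor of growth, a higher number a weaker inhibitor of growth), compound 1 gives 37900 nM, and compound 2 gives 70000 nM; the step of a 1.8-fold higher number from compound 1 to compound 2 (0.27 log units; within the scatter). Compound 3 `NC(=S)N/N=C1/C(=O)N(CN2CCN(c3ccnc4cc(Cl)ccc34)CC2)c2cc(Br)ccc21` carries a different core; how its core differs from that of compound 1 is not broken down here. In this assay compound 3 gives 22100 nM, which stands closest to compound 1 and furthest from compound 2 among the three measured compounds.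

Compound 4 `NC(=S)N/N=C1/C(=O)N(CN2CCN(c3ccnc4cc(Cl)ccc34)CC2)c2ccccc21` arises from compound 3 by hydrogen in place of bromo on an aromatic carbon. This is the same kind of change as that from compound 1 to compound 2, but the place differs: there the bromo sits ortho to a fused ring and meta to a fused ring, here meta to a fused ring and para to a fused ring. Among the measured compounds shown here, with only one measured instance of this kind of change, the expectation rests on that single step. Compound 4 is expected to move by a 1.6-fold higher number from compound 3 to compound 4 (0.20 log units; within the scatter) in this assay, by analogy with a 1.8-fold higher number from compound 1 to compound 2 (0.27 log units; within the scatter). Compound 4 is thus estimated at 35000 nM, expected between 15000 nM and 80000 nM.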

Compound 4, concentration for 50% growth inhibition: 27700 nM
Compound 4: middle estimate off by 1.3-fold (0.10 log units), on the high side, and the stated range covers the measured number.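

In this assay, hydrogen in place of bromo gives a 1.3-fold higher number from compound 3 to compound 4 (0.10 log units; within the scatter), and this step does not stand apart from the earlier one on the other core: the same change on two cores in this assay, a 1.8-fold higher number (0.27 log units; within the scatter) from compound 1 to compound 2 and a 1.3-fold higher number (0.10 log units; within the scatter) from compound 3 to compound 4, 1.5-fold (0.17 log units) apart, within the scatter of two such steps. The change therefore carries from one core to the other with no detectable difference in size, and as each step lies within the scatter, neither shows on its own that removing bromo affects growth inhibition in these cells. The comparison does not show that the step is independent of core or place, as the two pairs differ in both, with the bromo of compound 3 meta to a fused ring and para to a fused ring, and two pairs cannot establish a rule for the series.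

The compounds shown leave open how this step behaves with bromo at one fixed place on both cores. They also leave open whether a methoxy group, an amine or a carboxylic acid on the same aromatic carbon would give a step beyond the scatter.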